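The source may report more compounds than this note shows. Statements on the series, on what has been measured and on what is new or still open speak of the compounds shown alone.

Compound 1 `CC(C)C(Cc1ncc[nH]1)c1ccc(-c2ccc3cccc(F)c3c2)[nH]c1=O` sits at the limit of an ADME assay on microsomes from liver (Rattus norvegicus) for metabolic stability; a lower number here means that the compound disappears faster, a higher number that the compound lasts longer: in this run compound 1 gives < 0.0667 h, which is a limit of the assay and not a number, as recorded in the limit of < 0.0667 h in this assay, at which 1 of the 2 values shown sits. Compound 2 `CC(C)[C@@H](C[C@H]1CCNC1=O)c1ccc(-c2ccc3cccc(F)c3c2)[nH]c1=O` is the other measured member of the series; in this assay compound 2 gives 0.507 h. Among the compounds with values here, no step between measured compounds is available. Compound 3 `Cc1c[nH]c(C(c2ccc(-c3ccc4cccc(F)c4c3)[nH]c2=O)C(C)C)n1` differs from compound 1 by 4-methyl-1H-imidazol-2-yl in place of (1H-imidazol-2-yl)methyl on a saturated chain carbon bound to an aromatic carbon and a saturated chain carbon. With only a limit for compound 1, the expected step of an at least 1.4-fold higher number from compound 1 to compound 3 (0.17 log units; that floor lies within the scatter) is a modest rise, possibly no more than scatter. Compound 3 is estimated at 0.1 h, within 0.04 h to 0.3 h.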

Compound 3, half-life: < 0.0667 h
Compound 3 gave a limit, no number (the forecaster's own chance of this, stated with the estimate: 40%); middle value at least 1.4-fold (0.17 log units) away from the limit.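

Within the data shown here, compound 1 and compound 3 both give only a limit in this assay, so no step between them can be read: the limit of < 0.0667 h in this assay, at which 2 of the 3 values shown sit. From the compounds shown here alone, whether 4-methyl-1H-imidazol-2-yl in place of (1H-imidazol-2-yl)methyl shifts the half-life at all remains open.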